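Two Amides on a Shared Core: Swapping the Aryl Group

A few compounds are considered here, and "the series" means these few. Any claim that something is new, unique, unknown or untested is made for them only; others in the source may bear on it.

Three measured compounds share a core carrying two amide groups. In an assay on isolated protein for inhibition of Rho-associated protein kinase 2 (Homo sapiens), read by scintillation counting, radiometric assay and 33P incorporation, with a stated time of 40 min, in the presence of a further agent that is not named here (on this read-out lower numbers stand for stronger inhibition and higher numbers for weaker inhibition), compound 1 `CN(C)c1ccc(C(=O)Nc2cccc(NC(=O)COc3ccc4c(c3)CCC(=O)N4)c2)cc1` gives 9970 nM. Compound 2 `COc1ccc(OCC(=O)Nc2cccc(NC(=O)c3ccc(N(C)C)cc3)c2)cc1OC` gives > 10000 nM in this assay, which is a limit of the assay and not a number. Compound 3 `CC(C)(C)c1ccc(C(=O)Nc2cccc(NC(=O)COc3ccc4c(=O)ccoc4c3)c2)cc1` gives 34 nM in this assay, the lowest of the two numbers; its nearest neighbour is compound 1, and that gap lies well beyond the usual scatter. Going by the values given here, the single measured step, a number no lower from compound 1 to compound 2 (the limit leaves the size open), alters the group on the oxygen on a saturated carbon, and the limit of > 10000 nM in this assay, at which 1 of the 3 values shown sits, is where compound 2 sits.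

Compound 4 `Cc1nc(C(=O)Nc2cccc(NC(=O)COc3ccc4c(=O)ccoc4c3)c2)cs1` changes a different end of compound 3: 2-methyl-1,3-thiazol-4-yl in place of 4-(tert-butyl)phenyl on a carbonyl carbon. Among the compounds with values here, no measured step touches this carbonyl carbon, so the data give no guide to the size or direction of the change. Compound 4 is therefore estimated to give 150 nM, with a range from 30 nM to 1500 nM. This expectation amounts to a step of a 4.4-fold higher number from compound 3 to compound 4 (0.64 log units; beyond the scatter), allowing room for a weakening that remains unproven.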

Compound 4, half-maximal inhibitory concentration: 33 nM
Beside the measured number, compound 4's estimate is 4.5-fold (0.66 log units) above it; measured number inside the range.
By their numbers in this assay, from the lowest: compounds 4 and 3 (each within the scatter of the next); then compound 1. At a limit, above all of these: compound 2.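

Going by these compounds alone, at this carbonyl carbon, this assay gives a 1.0-fold lower number from compound 3 to compound 4 (0.01 log units; within the scatter), the first measured step at this place, and it shows that the two groups can be exchanged with the values of the two compounds staying within the scatter of each other. The exchange is not a small one in structure: a five-membered aromatic ring with 2 hydrogen-bond acceptors enters, while a six-membered aromatic ring of carbon only, with a tert-butyl group and no such acceptors, leaves. Nothing measured here explains why the two values lie so close.

Only these two groups can be compared directly on this carbonyl carbon, so the compounds shown do not tell how far this tolerance extends. From the compounds shown here alone, whether a carboxylic acid, a primary amine or a longer alkyl chain in the same place would give a similar number remains open.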